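Methoxyphenyl for nitrophenyl across two core variants

The source may hold more compounds than are shown below. What is called first, only, known or untested is meant among the compounds shown, and "the series" means these compounds.

In a functional assay on MDA-MB-231 cells (Homo sapiens) for inhibition, read by sulforhodamine B assay, with a stated time of 48 h (a lower number here means a stronger inhibitor of growth, a higher number a weaker inhibitor of growth), compound 1 `O=C(CCN1C(=O)CSc2ccccc21)N1CCN(c2ccc([N+](=O)[O-])cc2)CC1` gives 5600 nM. Its partner compound 2 `COc1ccccc1N1CCN(C(=O)CCN2C(=O)CSc3ccccc32)CC1` gives 6600 nM in this assay; the change between them is 2-methoxyphenyl in place of 4-nitrophenyl on an amine nitrogen in a ring, and the step of a 1.2-fold higher number from compound 1 to compound 2 (0.07 log units; within the scatter) is recorded as within the scatter. Compound 3 `O=C(CCN1C(=O)CSc2ccccc21)NCCCN1CCN(c2ccc([N+](=O)[O-])cc2)CC1` reports only a limit of this assay, > 100000 nM, which is the limit of > 100000 nM in this assay, at which 1 of the 3 values shown sits. How the core of compound 3 differs from that of compound 1 is not broken down here. Compound 4 `COc1ccccc1N1CCN(CCCNC(=O)CCN2C(=O)CSc3ccccc32)CC1` carries the same kind of change relative to compound 3, (2-methoxyphenyl in place of 4-nitrophenyl on an amine nitrogen in a ring), at a place described in the same words. Because the first pair moved by a 1.2-fold higher number from compound 1 to compound 2 (0.07 log units; within the scatter), the step from compound 3 to compound 4 is expected to be similarly small, a step that the limit leaves unreadable from compound 3 to compound 4. Compound 4 is therefore estimated at 150000 nM in this assay, most likely again only as a limit.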

Compound 4, concentration for 50% growth inhibition: 2000 nM
For compound 4 the middle estimate is 75-fold (1.88 log units) above the measured one; the measured number lies below the stated range.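

With 2-methoxyphenyl in place of 4-nitrophenyl, this assay shows an at least 50-fold lower number from compound 3 to compound 4 (1.69 log units; beyond the scatter), so the change does not carry over unaltered from the core of compound 1 to the core of compound 3: the same change on two cores in this assay, a 1.2-fold higher number (0.07 log units; within the scatter) from compound 1 to compound 2 and an at least 50-fold lower number (1.69 log units; beyond the scatter) from compound 3 to compound 4, at least 58-fold (1.77 log units) apart, beyond the scatter of two such steps.
Going by these compounds, compound 3 is recorded only as a limit, > 100000 nM, so the true size of that step stays unknown.
The two pairs show that the outcome of this change depends on the core in this series, but they do not show which feature of the core is responsible, or that the same would hold on any other core.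

Still open, on these data alone, is whether a plain phenyl or a chlorophenyl on the amine nitrogen in the ring would behave as the 2-methoxyphenyl does on the core of compound 3. Also open, as far as these compounds go, is how a longer chain in that core would affect the result.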